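Quinazoline selenoethers tested for toxicity toward leukemia cells

The source may hold more compounds than are shown below. What is called first, only, known or untested is meant among the compounds shown, and "the series" means these compounds.

Measured compounds and their values in a functional assay on CCRF-CEM cells (Homo sapiens) for cytotoxicity, read by MTT assay, with a stated time of 72 h; on this read-out lower numbers stand for higher toxicity in this test and higher numbers for lower toxicity in this test:
- Compound 1, `CCCCC[Se]c1nc(NCc2ccccc2)c2ccccc2n1`: > 100000 nM, a limit of the assay rather than a number.
- Compound 2, `CSc1ccc(CNc2nc([SeH])nc3ccccc23)cc1`: > 100000 nM, again a limit of the assay.
- Compound 3, `CCCCC[Se]c1nc(NCc2ccc(SC)cc2)c2ccccc2n1`: > 100000 nM, also a limit of the assay.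

Compound 3 therefore stands at the edge of what this assay can report, in line with the limit of > 100000 nM in this assay, at which 3 of the 3 values shown sit. The two steps that lead to it, a step that the two limits leave unreadable from compound 1 to compound 3 and a step that the two limits leave unreadable from compound 2 to compound 3, cannot be sized, since both ends sit at the limit. Compound 4, `CSc1ccc(CNc2nc([Se]C)nc3ccccc23)cc1`, differs from compound 3 by hydrogen in place of butyl on a saturated chain carbon bound to a selenium atom. For the measured compounds named here, no measured step involves a change of this kind, so nothing in the data points to a change beyond the scatter in either direction. The expectation for compound 4 is therefore a value at or near the limit, with an estimated step of a number no higher from compound 3 to compound 4 (the limit leaves the size open). Compound 4 is estimated at 100000 nM, within a range from 30000 nM to 300000 nM.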

Compound 4, concentration lethal to 50% of the cells: > 100000 nM
Compound 4 was reported as a limit; the forecaster's own chance of this, stated with the estimate: 80%; the middle value sits exactly at the limit.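

The steps from compound 3 to compound 4 and from compound 2 to compound 4 cannot be read, because both ends of each step are limits rather than numbers: the limit of > 100000 nM in this assay, at which 4 of the 4 values shown sit.

In this assay the compounds shown leave open whether changing the group on selenium, or adding methylsulfanyl, alters toxicity at all.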